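The source may report more compounds than this note shows. Statements on the series, on what has been measured and on what is new or still open speak of the compounds shown alone.

Measured so far:
compound 1, `CC1(C)CC(=O)N(c2ccccc2C(=O)OCC2CCCN(CCCc3ccccc3)C2)C1=O`, 7500 nM in a functional assay with Neuronal acetylcholine receptor; alpha3/beta4 (Homo sapiens) as the target; on this read-out higher numbers stand for weaker inhibition and lower numbers for stronger inhibition
compound 2, `O=C(OCC1CCCN(CCCc2ccccc2)C1)c1ccccc1N1C(=O)CC(C2CCCC2)C1=O`, 1200 nM

Compound 1 gives the highest of the two numbers in this assay; the nearest is compound 2, reached by a 6.3-fold lower number from compound 1 to compound 2 (0.80 log units; beyond the scatter).

Compound 3, `O=C(OCC1CCCN(CCCc2ccccc2)C1)c1ccccc1C(F)(F)F`, is not yet measured. It differs from compound 1 by trifluoromethyl in place of 3,3-dimethyl-2,5-dioxopyrrolidin-1-yl on an aromatic carbon. For the measured compounds named here, the only measured step touches the same position but swaps one ring-bearing group for another, so it guides the direction only loosely. The expected step is a 1.1-fold higher number from compound 1 to compound 3 (0.03 log units; within the scatter), with wide uncertainty. Compound 3 is therefore estimated at 8000 nM, in the range 2000 nM to 30000 nM.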

Compound 3, half-maximal inhibitory concentration: 3200 nM
Beside the measured number, compound 3's estimate is 2.5-fold (0.40 log units) above it, and the stated range covers the measured number.
By their numbers in this assay, from the lowest: compound 2; then compound 3; then compound 1.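

In this assay, the ring at this position proves dispensable: trifluoromethyl, with no ring and no hydrogen-bond acceptors, in place of 3,3-dimethyl-2,5-dioxopyrrolidin-1-yl gives a 2.3-fold lower number from compound 1 to compound 3 (0.37 log units; beyond the scatter). The two-ring group of compound 2 still gives the lowest number, since trifluoromethyl in its place gives a 2.7-fold higher number from compound 2 to compound 3 (0.43 log units; beyond the scatter). Nothing available explains either step.

Going by these compounds, whether size alone orders these three groups remains open. A single chlorine atom, a nitrile or an amine at this position could help test that.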